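The compounds below may be only part of what the source reports. "The series", "measured", "known", "first", "only" and "open" are said of these compounds alone.

Compound 1 `COc1cc(-c2cc(/C=C/C(=O)c3ccc(N)cc3)[nH]n2)cc(OC)c1OC` is studied in a functional assay on HT-29 cells (Homo sapiens) for inhibition, read by sulforhodamine B assay, with a stated time of 48 h; a lower number here means that less compound is tolerated, a higher number that more compound is tolerated. In this assay compound 1 gives only a limit, > 100000 nM, and not a number. Compound 1 therefore stands at the limit of > 100000 nM in this assay, at which 1 of the 3 values shown sits, the outer edge of what the three measured compounds show. Two further compounds share the core of compound 1 but carry other groups on the carbonyl carbon: compound 2 `COc1ccc(-c2cc(/C=C/C(=O)c3ccc(OC)c(OC)c3)[nH]n2)cc1` gives 7680 nM in this assay, and compound 3 `COc1ccc(-c2cc(/C=C/C(=O)c3cc(OC)c(OC)c(OC)c3)[nH]n2)cc1OC` gives 5750 nM. These two values lie within the usual scatter of each other, so no order between them is claimed.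

Compound 4 `COc1ccc(C(=O)/C=C/c2cc(-c3cc(OC)c(OC)c(OC)c3)n[nH]2)cc1OC` is not yet measured in this assay. It differs from compound 1 in one place: 3,4-dimethoxyphenyl in place of 4-aminophenyl on a carbonyl carbon. Among the measured compounds shown here, no step between two measured compounds differing in a single place is available. Compound 2 and compound 3 both give numbers inside the range of the assay, so compound 4 is expected to give a number rather than a limit. The step of an at least 15-fold lower number from compound 1 to compound 4 (1.18 log units; beyond the scatter) is expected to run toward a less tolerated compound, beyond the scatter. For compound 4 the estimated value in this assay is 6500 nM, with a range from 2000 nM to 25000 nM.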

Compound 4, concentration lethal to 50% of the cells: 5750 nM
Beside the measured number, compound 4's estimate is 1.1-fold (0.05 log units) above it; the range from low to high includes it.
By their numbers in this assay, from the lowest: compounds 3, 4 and 2 (each within the scatter of the next). At a limit, above all of these: compound 1.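

Setting 3,4-dimethoxyphenyl in place of 4-aminophenyl on a carbonyl carbon gives the first single change that can be read in this assay, and it amounts to an at least 17-fold lower number from compound 1 to compound 4 (1.24 log units; beyond the scatter). With the rest of the molecule the same, the group at this position alone separates a compound that gives a number from one that gives only a limit. The step is therefore a bound rather than an exact size, because compound 1 stands at a limit: the limit of > 100000 nM in this assay, at which 1 of the 4 values shown sits.

From the compounds shown here alone, what an unsubstituted phenyl, a 4-methoxyphenyl or a 4-hydroxyphenyl would give at this position remains open, so the step cannot be assigned to the loss of the amine or to the arrival of the methoxy groups. Also open, going by these compounds, is whether an acetamide in place of the amine would give a number or a limit.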